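Bromo for chloro on the shared core of two oxindole-type compounds

This account rests on a few compounds, and the source may have more. Where it says the series, first, only, none or still open, it means among the compounds named here.

This account concerns two measured compounds and one that awaits measurement. Compound 1, `COc1cc(Cn2cc(COc3cccc(/C=C4\C(=O)Nc5ccccc54)c3)nn2)cc(OC)c1`, was tested in a functional assay on A549 cells (Homo sapiens) for inhibition, read by MTT assay, with a stated time of 48 h (a lower number here means a stronger inhibitor, a higher number a weaker inhibitor), where compound 1 gives 43300 nM. Compound 2, `O=C1Nc2cc(Cl)ccc2/C1=C\c1cccc(OCc2cn(Cc3ccccc3)nn2)c1`, was tested in the same way. In this assay compound 2 reaches only a limit of the measurement, > 50000 nM, so no number is known for it; it sits at the limit of > 50000 nM in this assay, at which 1 of the 2 values shown sits. Compound 3, `O=C1Nc2cc(Br)ccc2/C1=C\c1cccc(OCc2cn(Cc3ccccc3)nn2)c1`, differs from compound 2 in one place: bromo in place of chloro on an aromatic carbon. Among the measured compounds shown here, no measured pair in this set shows the size of such a step. The exchange of one halogen for another of the same count of heavy atoms is expected to give a step that the limit leaves unreadable from compound 2 to compound 3 that stays within the scatter, in no settled direction. Compound 3 is therefore expected to give about 60000 nM in this assay, between 25000 nM and 150000 nM, and most likely again only a limit.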

Compound 3, half-maximal inhibitory concentration: 9600 nM
Compound 3: middle estimate off by 6.3-fold (0.80 log units), on the high side; the whole stated range lies above it.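

Bromo in place of chloro on this aromatic carbon gives an at least 5.2-fold lower number from compound 2 to compound 3 (0.71 log units; beyond the scatter) in this assay, so the exchange of one halogen for another at this place is enough to move the number beyond the scatter. That step is only a minimum, and its full size cannot be read, because compound 2 stands at a limit of the assay and not at a number: the limit of > 50000 nM in this assay, at which 1 of the 3 values shown sits. Compound 1 differs from compound 3 in more than one place, so it does not bear on this step.

The compounds shown leave open how this position would respond to iodo, fluoro or an amine. They also leave open whether bromo would give a step of similar size with the dimethoxy-bearing side chain of compound 1.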